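A pyrimidine amide follows two compounds at the limit

The source may hold more compounds than are shown below. What is called first, only, known or untested is meant among the compounds shown, and "the series" means these compounds.

In an ADME assay on LLC-MK2 cells (Macaca mulatta) for cytotoxicity, read by spectrophotometry and crystal violet staining, with a stated time of 4 days (on this read-out higher numbers stand for lower toxicity in this test and lower numbers for higher toxicity in this test), compound 1 (`CC(C)n1ncc2c(C(=O)Nc3ccc(F)cc3)cc(-c3cccs3)nc21`) gives > 200000 nM, which is a limit and not a number. Compound 2 (`CC(C)n1ncc2c(C(=O)Nc3ccc(F)c(F)c3)cc(-c3cccs3)nc21`) likewise gives only a limit, > 200000 nM. Within the data shown here, the sole measured step, a step that the two limits leave unreadable from compound 1 to compound 2, has no size to carry over, and both compounds share (the limit of > 200000 nM in this assay, at which 2 of the 2 values shown sit). Compound 3 (`CC(C)n1ncc2c(C(=O)Nc3cncnc3)cc(-c3cccs3)nc21`) differs from compound 2 by pyrimidin-5-yl in place of 3,4-difluorophenyl on an amide-type nitrogen. Among the measured compounds shown here, no measured step covers this exchange, so no change beyond the scatter is expected in this assay. The expected step is a number no higher from compound 2 to compound 3 (the limit leaves the size open). Compound 3 is estimated at 200000 nM, within an expected range of 110000 nM to 350000 nM.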

Compound 3, half-maximal cytotoxic concentration: 20000 nM
For compound 3 the middle estimate is 10-fold (1.00 log units) above the measured one; measured number below the stated range.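

The place on the amide nitrogen is not indifferent in this assay: pyrimidin-5-yl in place of 3,4-difluorophenyl gives an at least 10-fold lower number from compound 2 to compound 3 (1.00 log units; beyond the scatter), and pyrimidin-5-yl in place of 4-fluorophenyl gives an at least 10-fold lower number from compound 1 to compound 3 (1.00 log units; beyond the scatter). The step between the two fluorinated compounds could not be read, so this is the first change shown that registers here, and it points towards higher toxicity in this test. Both sizes are only minimum sizes because compound 1 and compound 2 sit at a limit: the limit of > 200000 nM in this assay, at which 2 of the 3 values shown sit.

The compounds shown leave open whether the ring nitrogens or the loss of the fluorines accounts for this change. They also leave open how a pyridyl or an unsubstituted phenyl group on the same nitrogen would read.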